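A Methyl on the Sulfanylmethyl Chain

The source may report more compounds than this note shows. Statements on the series, on what has been measured and on what is new or still open speak of the compounds shown alone.

In a functional assay on the whole organism (stomach, strain beagle) for inhibition, with Canis familiaris (Canis lupus familiaris) as the target, with a stated time of 2 h, at a dose of 8 mg/kg (on this read-out higher numbers stand for a stronger effect at the one dose given and lower numbers for a weaker effect), compound 1 `CC(C)(C)CNC(=N)CS` gives 95%, the higher of the two numbers recorded so far. Compound 2 `N=C(CS)NCc1ccccn1` gives 82% in this assay, a reading that lies beyond the scatter of the first, so compound 1 stands as the stronger of the two at the dose given. Among the measured compounds shown here, no step between two measured compounds that differ in one place is available, so the path from compound 1 to compound 3 `CC(S)C(=N)NCC(C)(C)C` rests on the structural change alone: methyl in place of hydrogen on a saturated chain carbon bound to a carbon with a double bond to nitrogen and a sulfur, read one bond further out as sulfanylmethyl to 1-sulfanylethyl. Since compound 1 already sits near the top of the scale, the author expects little room upward and a step that is small, if anything downward, and likely within the scatter. Compound 3 is expected to give about 88% in this assay, between 70% and 98%. The step this estimate implies, a number 7 percentage points lower from compound 1 to compound 3 (within the scatter), is expected to stay within the usual scatter.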

Compound 3, a percentage reported as inhibition, in the whole organism at one dose (the size of the read-out at that dose, not a potency): 0%
Compound 3: the middle estimate sits 88 percentage points above what was measured; the whole stated range lies above it.
By their numbers in this assay, from the lowest: compound 3; then compound 2; then compound 1.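

Both earlier compounds carry the sulfanylmethyl chain, so they said nothing about the saturated chain carbon bound to a carbon with a double bond to nitrogen and a sulfur. In this assay, the change from sulfanylmethyl to 1-sulfanylethyl brings a number 95 percentage points lower from compound 1 to compound 3 (beyond the scatter), which shows that, in the core of compound 1, the effect at the one dose given depends on this carbon keeping its hydrogen in place of a methyl. No measurement at hand bears on why this single added methyl has so large an effect.

As far as these compounds go, whether an ethyl or a fluorine on the same carbon would behave like the methyl stays open. So does whether compound 3 would show any effect at a higher dose, and whether the same methyl would have this effect in the core of compound 2.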